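The compounds below may be only part of what the source reports. "The series", "measured", "known", "first", "only" and "open" are said of these compounds alone.

Measured so far:
- compound 1 `COc1ccc(C(=O)/C=C/c2cc(-c3cc(OC)c(OC)c(OC)c3)n[nH]2)cc1OC`; in a functional assay on RPMI-8226 cells (Homo sapiens) for cytotoxicity, read by sulforhodamine B assay, with a stated time of 48 h, tested at 0.01 uM (on this read-out lower numbers stand for a stronger effect and higher numbers for a weaker effect at the one concentration tested), compound 1 gives 94%
- compound 2 `COc1ccc(C(=O)/C=C/c2cc(-c3cc(OC)c(OC)c(OC)c3)n[nH]2)cc1`; in this assay compound 2 gives 98%

Going by the values given here, the only step between these two, a number 4 percentage points higher from compound 1 to compound 2 (within the scatter), shows that swapping hydrogen in for methoxy on an aromatic carbon left the read-out essentially where it was; compound 2 sits within the scatter of compound 1, and nothing separates the two. Both values lie close to the top of the percentage scale, which means that neither compound shows much effect at the single low concentration tested.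

Compound 3 `COc1cc(-c2cc(/C=C/C(=O)c3ccc(F)c(F)c3)[nH]n2)cc(OC)c1OC` has not been measured. It differs from compound 2 by 3,4-difluorophenyl in place of 4-methoxyphenyl on a carbonyl carbon. Among the compounds with values here, no measured step touches this part of the molecule or this kind of exchange, so the single step seen so far, which stayed within the scatter, is the only guide. The step from compound 2 to compound 3 is expected to be a number 3 percentage points lower from compound 2 to compound 3 (within the scatter), that is, none beyond the scatter. Compound 3 is therefore estimated at 95%, with a range from 82% to 105%.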

Compound 3, a percentage reported as activity, at one concentration (the size of the read-out at that concentration, not a potency): 94%
Estimate against measurement, compound 3: 1 percentage points above; the measured number falls inside the stated range.
By their numbers in this assay, from the lowest: compounds 1, 3 and 2 (each within the scatter of the next).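

Replacing the group on the carbonyl carbon gives a number 4 percentage points lower from compound 2 to compound 3 (within the scatter) when 3,4-difluorophenyl enters for 4-methoxyphenyl, and no change at the digits printed from compound 1 to compound 3 (within the scatter) when it enters for 3,4-dimethoxyphenyl. The earlier step removed only a methoxy group, whereas these two exchange the ring's substituents for fluorine, leaving no methoxy on that ring, and this assay still separates none of the three compounds. All three stay near the top of the scale at the one low concentration tested, so this position has so far shown no measurable response to these exchanges, and no available evidence gives a reason for that. From the compounds shown here alone, it remains open whether a ring bearing an amine or a carboxylic acid on this carbonyl carbon would read differently. The same question holds for a longer chain there.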